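A few compounds are considered here, and "the series" means these few. Any claim that something is new, unique, unknown or untested is made for them only; others in the source may bear on it.

Measured so far in a functional assay, read by spectrophotometry, with a stated time of 10 min; a higher number here means that more compound is needed for the effect, a lower number that less compound is needed

compound 1 `COC(=O)C1=C(C)NC(=O)NC1c1ccc(OC)cc1` gives 1.92 ug/mL
compound 2 `COC(=O)C1=C(C)NC(=O)NC1c1cccc([N+](=O)[O-])c1` gives 1.6 ug/mL

Only these two numbers are available. Compound 2 (1.6 ug/mL) and compound 1 (1.92 ug/mL) lie within the usual scatter of each other, so neither stands apart.

The next compound to be measured is compound 3 `COC(=O)C1=C(C)NC(=O)NC1c1ccccc1`, which has hydrogen in place of nitro on an aromatic carbon. The shared core stays unchanged. Going by the values given here, no step between measured compounds that differ in one place is available, so the expectation rests on a thin basis. The two aromatic substituents seen so far give values within the scatter, compound 1 at 1.92 ug/mL and compound 2 at 1.6 ug/mL.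

The expected step in this assay is therefore none beyond the scatter (a 1.1-fold higher number from compound 2 to compound 3 (0.05 log units; within the scatter)). Compound 3 is estimated at 1.8 ug/mL (expected range 0.9 ug/mL to 3.6 ug/mL).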

Compound 3, half-maximal effective concentration: 2.23 ug/mL
Beside the measured number, compound 3's estimate is 1.2-fold (0.09 log units) below it; low and high end bracket the measured number.
By their numbers in this assay, from the lowest: compounds 2, 1 and 3 (each within the scatter of the next).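

Compound 3 gives the series a reference with hydrogen on the aromatic ring. In this assay, the two comparisons that differ in one place read a 1.4-fold higher number from compound 2 to compound 3 (0.14 log units; within the scatter) for hydrogen in place of nitro and a 1.2-fold higher number from compound 1 to compound 3 (0.07 log units; within the scatter) for hydrogen in place of methoxy. Neither nitro nor methoxy is therefore set apart from hydrogen in these numbers, and nothing at hand accounts for the readings or tells whether the two groups truly match hydrogen.

From the compounds shown here alone, whether any group on the aromatic ring can move the number beyond the scatter stays open, for example an amine, a carboxylic acid or chlorine. Also open, going by these compounds, is what a longer chain in place of the methyl on the ester of the shared core would do.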